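Arginine-type side chain on the glutamate-derived purine amide series

A few compounds are considered here, and "the series" means these few. Any claim that something is new, unique, unknown or untested is made for them only; others in the source may bear on it.

Compound 1 `O=C(O)CC[C@H](NC(=O)CN(c1nc(Cl)nc2[nH]cnc12)C1CC1)C(=O)O`: 30.1%
Compound 2 `NC(=O)CC[C@H](NC(=O)CN(c1nc(Cl)nc2[nH]cnc12)C1CC1)C(=O)O`: 17.8%
Compound 3 `CSCC[C@H](NC(=O)CN(c1nc(Cl)nc2[nH]cnc12)C1CC1)C(=O)O`: 5.67%

In a functional assay on the whole organism (Tail, strain ICR) with Mus musculus as the target, in the tail flick test, with a stated time of 120 min, at a dose of 25 umol/kg by the oral route (a higher number here means a stronger effect of the compound at the dose given, a lower number a weaker effect), compound 3 stands lowest of the three measured compounds, with compound 2 nearest and compound 1 furthest. Compound 4 `N=C(N)NCCC[C@H](NC(=O)CN(c1nc(Cl)nc2[nH]cnc12)C1CC1)C(=O)O` differs from compound 3 by a group of 5 heavy atoms (2 carbon, 3 nitrogen; no ring) in place of a group of 2 heavy atoms (1 carbon, 1 sulfur; no ring), on a saturated chain carbon, three bonds along the chain from an amide-type nitrogen and a carbonyl carbon. Going by the values given here, two measured steps bear on this place: a number 24.4 percentage points lower from compound 1 to compound 3 (beyond the scatter) and a number 12.1 percentage points lower from compound 2 to compound 3 (beyond the scatter), both lowering the read-out when methylsulfanyl entered. Reversing that direction, a rise beyond the scatter is expected for compound 4, though its size is uncertain since no guanidine-bearing analog has been measured. Compound 4 is therefore estimated at 20%, within 5% to 38%, an expected step of a number 14.3 percentage points higher from compound 3 to compound 4 (beyond the scatter).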

Compound 4, a percentage reported as activity, at one dose (the size of the read-out at that dose, not a potency): 17%
For compound 4 the middle estimate is 3 percentage points above the measured one; low and high end bracket the measured number.
By their numbers in this assay, from the lowest: compound 3; then compounds 4 and 2 (each within the scatter of the next); then compound 1.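

At this place on the saturated chain, the group of 5 heavy atoms in place of methylsulfanyl gives a number 11.3 percentage points higher from compound 3 to compound 4 (beyond the scatter) in this assay, so a chain without a carbonyl group can still recover part of the read-out. Set against the carbamoyl chain, it gives a number 0.8 percentage points lower from compound 2 to compound 4 (within the scatter), while against the carboxylic acid chain it gives a number 13.1 percentage points lower from compound 1 to compound 4 (beyond the scatter), which leaves compound 1 highest of the four. No evidence is available to explain these differences. On these data alone, whether a plain amine at the chain end, or a longer chain bearing a carboxylic acid, would match compound 1 remains open.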